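Adding phenylsulfonyl to a compound with low toxicity

The compounds below may be only part of what the source reports. "The series", "measured", "known", "first", "only" and "open" are said of these compounds alone.

- Compound 1 `O=C(OC[C@H]1O[C@@H](n2cnc3c(Cl)ncnc32)[C@H](O)[C@@H]1O)c1ccccc1` gives 97300 nM
- Compound 2 `OC[C@H]1O[C@@H](n2cnc3c(Cl)ncnc32)C[C@@H]1O` gives 173000 nM

These two values come from an ADME assay on Huh-7 cells (Homo sapiens) for cytotoxicity, read by XTT assay; on this read-out higher numbers stand for lower toxicity in this test and lower numbers for higher toxicity in this test. Compound 2 stands within the usual scatter of compound 1, so the two cannot be ranked against each other.

The next compound is made from compound 2 by a single change. Compound 3 `O=S(=O)(OC[C@H]1O[C@@H](n2cnc3c(Cl)ncnc32)C[C@@H]1O)c1ccccc1` has phenylsulfonyl in place of hydrogen on an oxygen on a saturated carbon. Going by the values given here, no measured pair shows the effect of this exact change, so the expectation rests on thin evidence. Among the compounds with values here, the only guide is compound 1, which also carries a six-membered aromatic ring of carbon only and gives 97300 nM in this assay, a value not clearly apart from that of compound 2. A large shift therefore seems unlikely, although a moderate move toward lower numbers, meaning higher toxicity in this test, is expected. The estimated change is a 2.5-fold lower number from compound 2 to compound 3 (0.39 log units; beyond the scatter) and it may prove to lie close to the scatter. The expected value for compound 3 is 70000 nM within an estimated range of 20000 nM to 200000 nM in this test.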

Compound 3, half-maximal cytotoxic concentration: 146000 nM
For compound 3 the middle estimate is 2.1-fold (0.32 log units) below the measured one; low and high end bracket the measured number.
By their numbers in this assay, from the lowest: compounds 1, 3 and 2 (each within the scatter of the next).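

Replacing hydrogen with phenylsulfonyl on an oxygen on a saturated carbon gives, in this assay, a 1.2-fold lower number from compound 2 to compound 3 (0.07 log units; within the scatter), so the two compounds cannot be ranked against each other. Going by these compounds alone, this is the first direct reading of a change at this oxygen, since compound 1 and compound 2 differ in more than one place and their values could not isolate any single change. In this one pair, a lone hydrogen gives way to a much larger group carrying a six-membered aromatic ring of carbon only, with no shift beyond the scatter, though nothing available offers a reason for this result.

The compounds shown leave open whether other groups on the same oxygen, such as methylsulfonyl, acetyl, a longer chain ending in an amine or one ending in a carboxylic acid, would also stay within the scatter of compound 2. They also leave open whether phenylsulfonyl would behave the same way on another core, as a single pair cannot establish a general rule for this change.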